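Shortening the acyl chain of an acylguanidine antiproliferative

The source may hold more compounds than are shown below. What is called first, only, known or untested is meant among the compounds shown, and "the series" means these compounds.

Two acylguanidines have been tested in a functional assay on MCF7 cells (Homo sapiens) for inhibition, read by MTT assay, with a stated time of 72 h; a higher number here means a weaker inhibitor of growth, a lower number a stronger inhibitor of growth. Compound 1 `C=C1CCCC(C)(C)[C@@H]1CC/C(C)=C/C(=O)NC(=N)NC(=O)C=C(C)C` gives 28100 nM. Compound 2 `CC(C)=CCC/C(C)=C/CC/C(C)=C/C(=O)NC(=N)NC(=O)C=C(C)C` gives 23400 nM, a number that stands together with that of compound 1, the two lying within the scatter of each other, so neither can be placed ahead of the other. Compound 3 `CC(C)=CCC/C(C)=C/C(=O)NC(=N)NC(=O)C=C(C)C` has not yet been measured. It differs from compound 2 only in the acyl chain: hydrogen in place of 3-methylbut-2-en-1-yl on a saturated chain carbon bound to a double-bonded chain carbon. Within the data shown here, no measured pair in this set shows the effect of such a truncation, so the step has to be judged from compound 2 alone, whose value of 23400 nM already lies in the weak range. On that basis compound 3 is expected to stay close to compound 2, with a step of a 1.5-fold higher number from compound 2 to compound 3 (0.19 log units; within the scatter) that is estimated to be small and, if anything, toward a higher number. Compound 3 is thus estimated at 36000 nM, within a range from 12000 nM to 110000 nM.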

Compound 3, concentration for 50% growth inhibition: 41500 nM
For compound 3 the middle estimate is 1.2-fold (0.06 log units) below the measured one; the measured number falls inside the stated range.
By their numbers in this assay, from the lowest: compounds 2, 1 and 3 (each within the scatter of the next).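

Among these compounds, replacing the 3-methylbut-2-en-1-yl group with hydrogen on a saturated chain carbon bound to a double-bonded chain carbon gives, in this assay, a 1.8-fold higher number from compound 2 to compound 3 (0.25 log units; within the scatter) and this is the first measured step at this position. The five carbons and the double bond of that group can therefore be lost from the acyl chain of compound 2 with a result that stays within the scatter of this assay, so the data do not show that this group matters for growth inhibition in these cells. Nothing measured here accounts for these numbers.

As far as these compounds go, whether a longer chain, an amine or a carboxylic acid on this carbon would give a step beyond the scatter remains open. So does whether a methyl group there would read the same as the groups in compound 2 and compound 3.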